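Notes on the step from compound 2 to compound 3

The source may report more compounds than this note shows. Statements on the series, on what has been measured and on what is new or still open speak of the compounds shown alone.

Compound 1 `COc1ccc(C(=O)c2cc(OC)c(OC)c(OC)c2)cc1N` gives 80 nM in a functional assay on ME-180 cells (Homo sapiens) for cytotoxicity, read by MTT assay, with a stated time of 72 h; on this read-out higher numbers stand for weaker inhibition and lower numbers for stronger inhibition. Compound 2 `COc1ccc(C(=O)c2cc(OC)c(OC)c(OC)c2)cc1NC(=O)/C=C/c1cc(OC)c(OC)c(OC)c1` gives 2100 nM in this assay and stands highest of the two numbers, with compound 1 the nearest and that gap beyond the scatter. Compound 3 `COc1ccc(/C=C/C(=O)Nc2cc(C(=O)c3cc(OC)c(OC)c(OC)c3)ccc2OC)cc1` differs from compound 2 by 4-methoxyphenyl in place of 3,4,5-trimethoxyphenyl on a double-bonded chain carbon bound to a double-bonded chain carbon. Among the measured compounds shown here, no measured pair shows how this change acts in this assay, so the expectation rests on compound 2 alone. The step of a 1.4-fold higher number from compound 2 to compound 3 (0.15 log units; within the scatter) is expected to be small, within the scatter, with no clear direction. Compound 3 is estimated at 3000 nM in this assay, ranging from 800 nM to 12000 nM.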

Compound 3, half-maximal inhibitory concentration: 11800 nM
Compound 3: middle estimate off by 3.9-fold (0.59 log units), on the low side, and the stated range covers the measured number.
By their numbers in this assay, from the lowest: compound 1; then compound 2; then compound 3.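

With 4-methoxyphenyl in place of 3,4,5-trimethoxyphenyl on a double-bonded chain carbon bound to a double-bonded chain carbon, the series moves a 5.6-fold higher number from compound 2 to compound 3 (0.75 log units; beyond the scatter) in this assay and this modest step points to weaker inhibition. The aryl group at this place therefore affects the read-out, and of the two groups shown, 3,4,5-trimethoxyphenyl gives the lower number. Nothing measured here explains the step. Which of the methoxy groups lost accounts for the step remains open. So does the effect at this place of a group such as an amine or a carboxylic acid on the phenyl ring.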